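The source may report more compounds than this note shows. Statements on the series, on what has been measured and on what is new or still open speak of the compounds shown alone.

Four related compounds share one core and differ at two outer positions. Compound 1 `COc1cc(-c2nc(-c3ccccc3)[nH]c2-c2ccnc(NCCCNS(=O)(=O)c3ccc(Br)cc3)n2)ccc1F` carries a bromo group on a phenylsulfonyl ring and a methoxy group on another aromatic ring. In a functional assay on LOX IMVI cells (Homo sapiens) for cytotoxicity, read by MTT assay, with a stated time of 24 h (on this read-out higher numbers stand for weaker inhibition and lower numbers for stronger inhibition), compound 1 gives 33900 nM. Compound 2 `COc1cc(-c2nc(-c3ccccc3)[nH]c2-c2ccnc(NCCCNS(=O)(=O)c3ccc(F)cc3)n2)ccc1F` differs from compound 1 by fluoro in place of bromo on an aromatic carbon and in this assay compound 2 gives 3960 nM, so there is an 8.6-fold lower number from compound 1 to compound 2 (0.93 log units; beyond the scatter). Compound 3 `O=S(=O)(NCCCNc1nccc(-c2[nH]c(-c3ccccc3)nc2-c2ccc(F)c(O)c2)n1)c1ccc(Br)cc1` differs from compound 1 by hydrogen in place of methyl on an oxygen on an aromatic ring, and in this assay compound 3 gives 5660 nM, which is a 6.0-fold lower number from compound 1 to compound 3 (0.78 log units; beyond the scatter). The values of compound 2 and compound 3 lie within the usual scatter of each other.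

Compound 4 `O=S(=O)(NCCCNc1nccc(-c2[nH]c(-c3ccccc3)nc2-c2ccc(F)c(O)c2)n1)c1ccc(F)cc1` has not yet been measured. It differs from compound 3 by fluoro in place of bromo on an aromatic carbon, the same change, at the same place, that turns compound 1 into compound 2. Among the compounds with values here, the only guide to its effect is that single pair, where the step was an 8.6-fold lower number from compound 1 to compound 2 (0.93 log units; beyond the scatter). Within the data shown here, whether the same step recurs on the hydroxy core of compound 3 is unknown, since no second example exists, so a somewhat smaller step is expected, with wide uncertainty. Starting from compound 3 and its value 5660 nM, the step to compound 4 is expected to be a 5.7-fold lower number from compound 3 to compound 4 (0.75 log units; beyond the scatter). Compound 4 is therefore estimated to give 1000 nM in this assay, with a likely range from 300 nM to 3500 nM.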

Compound 4, half-maximal inhibitory concentration: 19200 nM
Estimate against measurement, compound 4: 19-fold (1.28 log units) below; measured number above the stated range.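

In this assay, the change from 4-bromophenyl to 4-fluorophenyl gives a 3.4-fold higher number from compound 3 to compound 4 (0.53 log units; beyond the scatter), so on the core with the hydroxy group the step runs in the opposite direction to the one seen on the core with the methoxy group: the same change on two cores in this assay, an 8.6-fold lower number (0.93 log units; beyond the scatter) from compound 1 to compound 2 and a 3.4-fold higher number (0.53 log units; beyond the scatter) from compound 3 to compound 4, 29-fold (1.46 log units) apart, beyond the scatter of two such steps. Removing the methyl group from the oxygen shows the same kind of reversal, giving a 4.8-fold higher number from compound 2 to compound 4 (0.69 log units; beyond the scatter) when the fluoro group is present, whereas the same change lowered the number when the bromo group was present: the same change on two cores in this assay, a 6.0-fold lower number (0.78 log units; beyond the scatter) from compound 1 to compound 3 and a 4.8-fold higher number (0.69 log units; beyond the scatter) from compound 2 to compound 4, 29-fold (1.46 log units) apart, beyond the scatter of two such steps. The two changes therefore do not act independently in these four compounds, so a step measured on one core cannot simply be carried over to the other, but four compounds cannot show why the two positions depend on each other or whether other groups would behave the same way.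

The compounds shown leave open what a chloro group or a plain hydrogen in place of the bromo would do on each core, and whether an ethoxy group or an amine in place of the methoxy would follow either pattern. They also leave open whether the reversal would persist with a longer chain linking the sulfonyl amino group to the shared core.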